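Hydroxy for propyl on the imine chain of a coumarin series

The compounds below may be only part of what the source reports. "The series", "measured", "known", "first", "only" and "open" are said of these compounds alone.

Measured compounds:
compound 1 `CCCCCC/N=C(\C)c1c(O)c2ccccc2oc1=O`, 2900 nM
compound 2 `CC/C(=N\Cc1ccccc1)c1c(O)c2ccccc2oc1=O`, >= 100000 nM

In an assay on isolated protein for inhibition of myosin-2 (Bos taurus), read by spectrophotometry, with a stated time of 24 min (on this read-out lower numbers stand for stronger inhibition and higher numbers for weaker inhibition), compound 1 gives 2900 nM, the only number shown. For compound 2 the value >= 100000 nM is a limit of the assay, not a number. Compound 3 `C/C(=N\CCCO)c1c(O)c2ccccc2oc1=O` differs from compound 1 by hydroxy in place of propyl on a saturated chain carbon, three bonds along the chain from a double-bonded nitrogen. For the measured compounds named here, no measured step links two compounds that differ in one place, so the size of this change is untested. It is expected to be a loss of potency beyond the scatter, a 3.4-fold higher number from compound 1 to compound 3 (0.54 log units; beyond the scatter). Compound 3 is estimated at 10000 nM, within 3000 nM to 40000 nM.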

Compound 3, half-maximal inhibitory concentration: 37000 nM
For compound 3 the middle estimate is 3.7-fold (0.57 log units) below the measured one, and the stated range covers the measured number.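

Hydroxy is no neutral replacement for propyl at this place on the chain: in this assay the change gives a 13-fold higher number from compound 1 to compound 3 (1.11 log units; beyond the scatter). Inhibition is weakened but remains measurable, which gives the series its first sized step at this position. Only compound 2 sits at a limit, so the step from the hexyl chain to the 3-hydroxypropyl chain is read in full: the limit of >= 100000 nM in this assay, at which 1 of the 3 values shown sits.

Going by these compounds, whether the loss follows the hydroxy itself or the shorter chain remains open, since the change alters both at once. A plain propyl chain, a methoxy or an amine at the chain end would separate these readings.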